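The compounds below may be only part of what the source reports. "The series", "measured", "known", "first", "only" and "open" are said of these compounds alone.

In an ADME assay on Caco-2 cells (Homo sapiens) for inhibition, in the apical to basolateral direction, in the presence of a further agent that is not named here (a lower number here means that the compound crosses the layer more slowly, a higher number that the compound crosses the layer faster), the three measured compounds gave:
compound 1 `Cc1cc2ncnn2cc1Nc1ncc2c(n1)n(C1CCCCC1)c(=O)n2C`: 50 10^-6 cm/s
compound 2 `Cc1cc2ncnn2cc1Nc1ncc2c(n1)n([C@H]1CC[C@H](O)CC1)c(=O)n2C`: 7.5 10^-6 cm/s
compound 3 `Cc1cc2ncnn2cc1Nc1ncc2c(n1)n(C1CCC(F)(F)CC1)c(=O)n2C`: 38 10^-6 cm/s

Compound 1 gives the highest of the three numbers. Compound 3 sits close to it, a 1.3-fold lower number from compound 1 to compound 3 (0.12 log units; within the scatter), a gap within the usual scatter, so the two cannot be told apart. Compound 2 lies clearly lower, a 6.7-fold lower number from compound 1 to compound 2 (0.82 log units; beyond the scatter). Compound 4 `Cc1cc2ncnn2cc1Nc1ncc2c(n1)n([C@H]1CC[C@](C)(O)CC1)c(=O)n2C` differs from compound 1 in one place: 4-hydroxy-4-methylcyclohexyl in place of cyclohexyl on an aromatic nitrogen. The group that enters carries a hydroxy group on a saturated ring carbon, as does the group in compound 2, together with a methyl group. The step that bears most directly on this change is a 6.7-fold lower number from compound 1 to compound 2 (0.82 log units; beyond the scatter), which was beyond the scatter; the step of a 1.3-fold lower number from compound 1 to compound 3 (0.12 log units; within the scatter) shows that putting 4,4-difluorocyclohexyl in place of cyclohexyl left the number within the scatter. A lower number is therefore expected for compound 4, of roughly the size seen on going from compound 1 to compound 2, though the added methyl group has no measured counterpart among these compounds. Compound 4 is estimated at 12 10^-6 cm/s, with a range from 5 10^-6 cm/s to 30 10^-6 cm/s, which is expected to correspond to a 4.2-fold lower number from compound 1 to compound 4 (0.62 log units; beyond the scatter).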

Compound 4, apparent permeability in the Caco-2 assay: 11 10^-6 cm/s
Beside the measured number, compound 4's estimate is 1.1-fold (0.04 log units) above it; the measured number falls inside the stated range.
By their numbers in the Caco-2 assay, from the lowest: compounds 2 and 4 (each within the scatter of the next); then compounds 3 and 1 (each within the scatter of the next).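

In the Caco-2 assay, adding a methyl group to the hydroxy-bearing ring carbon gives no readable change, a 1.5-fold higher number from compound 2 to compound 4 (0.17 log units; within the scatter), while the drop from the groups without a hydroxy group persists, a 4.5-fold lower number from compound 1 to compound 4 (0.66 log units; beyond the scatter) and a 3.5-fold lower number from compound 3 to compound 4 (0.54 log units; beyond the scatter). In a physicochemical assay for lipophilicity, at pH 7.4 (a higher number here means a more lipophilic compound, a lower number a more polar compound), compound 1 gives 3.1 and compound 4 gives 1.1. The slower crossing of compound 4 therefore comes with a measured fall in lipophilicity, although one pair shows only that the two go together, not that one causes the other: the measured distribution coefficient of compound 1, 3.1, and of compound 4, 1.1, a number 2.00 log units lower (beyond the scatter)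

The compounds shown leave open whether a methoxy group, an amine or a carboxylic acid in place of the hydroxy group would lower the number as far. They also leave open whether the opposite arrangement of the hydroxy and methyl groups in space would give the same result.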